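A few compounds are considered here, and "the series" means these few. Any claim that something is new, unique, unknown or untested is made for them only; others in the source may bear on it.

Compound 1 `O=S(=O)(/C=C/c1ccc(Cl)cc1Cl)Cc1ccc(Nc2ncnc3ccccc23)cc1`: 4000 nM
Compound 2 `O=S(=O)(/C=C/c1ccc(Cl)cc1Cl)Cc1ccc(Nc2ncnc3cc(Cl)ccc23)cc1`: > 100000 nM

In a functional assay on OVCAR-8 cells (Homo sapiens) (on this read-out lower numbers stand for stronger inhibition of growth and higher numbers for weaker inhibition of growth), compound 2 is reported only as a limit, > 100000 nM. Compound 3 `O=S(=O)(/C=C/c1ccc(F)cc1Cl)Cc1ccc(Nc2ncnc3cc(Cl)ccc23)cc1` differs from it by fluoro in place of chloro on an aromatic carbon, para to a large group, so that 2,4-dichlorophenyl becomes 2-chloro-4-fluorophenyl. Among the measured compounds shown here, the only measured step is an at least 25-fold higher number from compound 1 to compound 2 (1.39 log units; beyond the scatter), a large one, for chloro in place of hydrogen on an aromatic carbon. That step lies outside the 2,4-dichlorophenyl group, so it bears on the new change only indirectly. Compound 3 keeps the chloro introduced in an at least 25-fold higher number from compound 1 to compound 2 (1.39 log units; beyond the scatter), so it is expected to remain weak, with at best a modest move towards lower numbers. The expected change is an at least 1.4-fold lower number from compound 2 to compound 3 (0.15 log units; that floor lies within the scatter), and another report of only a limit is quite possible. For compound 3 the estimate is 70000 nM, with an expected range of 15000 nM to 200000 nM.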

Compound 3, concentration for 50% growth inhibition: > 100000 nM
Compound 3: no number, only a limit (the forecaster's own chance of this, stated with the estimate: 50%); middle value at least 1.4-fold (0.15 log units) from the limit.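

Compound 2 and compound 3 are both reported in this assay only as limits, so the step between them cannot be read: the limit of > 100000 nM in this assay, at which 2 of the 3 values shown sit.

The compounds shown leave open whether fluoro in place of chloro on an aromatic carbon changes growth inhibition at all.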